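Swapping 4-carboxyphenyl for 1H-benzimidazol-6-yl on the amide

The source may report more compounds than this note shows. Statements on the series, on what has been measured and on what is new or still open speak of the compounds shown alone.

Compound 1 `C=C(CC)C(=O)c1ccc(OCC(=O)NCC(=O)O)c(Cl)c1Cl`: > 25000 nM (a limit)
Compound 2 `C=C(CC)C(=O)c1ccc(OCC(=O)Nc2ccc(C(=O)O)cc2)c(Cl)c1Cl`: 5000 nM

Among the compounds with values here, in a functional assay on CLL cells (Homo sapiens) for cytotoxicity, read by MTT assay, with a stated time of 48 h (on this read-out higher numbers stand for an effect only at larger amounts of compound and lower numbers for an effect already at smaller amounts), compound 2 gives 5000 nM, the only true number so far. Compound 1 gives > 25000 nM, which is a limit of the assay and not a number.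

Compound 3 `C=C(CC)C(=O)c1ccc(OCC(=O)Nc2ccc3nc[nH]c3c2)c(Cl)c1Cl` has not yet been measured. It carries 1H-benzimidazol-6-yl in place of 4-carboxyphenyl on an amide-type nitrogen.

Within the data shown here, one measured step bears on this change: an at least 5.0-fold lower number from compound 1 to compound 2 (0.69 log units; beyond the scatter), with 4-carboxyphenyl in place of carboxymethyl at that same nitrogen. On these data alone, its exact size is unknown because of the limit of > 25000 nM in this assay, at which 1 of the 2 values shown sits. That step says nothing directly about the entering group, so any forecast is loose. Both groups in the present swap contain a six-membered aromatic ring of carbon only. Since compound 2 reached 5000 nM with such a ring, no return towards compound 1 is expected.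

The expected step is a 1.7-fold lower number from compound 2 to compound 3 (0.22 log units; within the scatter) in this assay, a slight move to a lower number at most. For compound 3 the estimate is 3000 nM, with an expected range from 800 nM to 12000 nM.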

Compound 3, half-maximal effective concentration: 3200 nM
The estimate for compound 3 lay 1.1-fold (0.03 log units) below the measured number; the range from low to high includes it.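

In this assay, there is a 1.6-fold lower number from compound 2 to compound 3 (0.19 log units; within the scatter), so on this read-out 1H-benzimidazol-6-yl and 4-carboxyphenyl cannot be told apart on the amide nitrogen. This shows that the carboxyl group of compound 2 is not required to reach this level of effect, as compound 3 carries two ring nitrogens in place of the two oxygen atoms of that group. Measured against the carboxymethyl group, there is an at least 7.8-fold lower number from compound 1 to compound 3 (0.89 log units; beyond the scatter), so two different aromatic groups on this nitrogen now go with a step beyond the scatter, and the exact size of this step stays unknown because compound 1 stands at a limit of the assay and not at a number: the limit of > 25000 nM in this assay, at which 1 of the 3 values shown sits.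

A plain phenyl group on the same nitrogen would test whether the aromatic ring alone is enough, without either the carboxyl group or the ring nitrogens. A longer chain ending in a carboxylic acid, or a phenyl ring bearing an amine, would test whether the gain over compound 1 depends on an aromatic ring or on the kind of group attached to it.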